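The source may hold more compounds than are shown below. What is called first, only, known or untested is meant among the compounds shown, and "the series" means these compounds.

Compound 2 `NC(=O)CN(Cc1ccc(Cl)cc1)Cc1ccc([N+](=O)[O-])s1` carries a carbamoyl group on the chain carbon bound to the amine nitrogen. The measurements come from a functional assay on HEK293 cells for agonist activity at nuclear receptor subfamily 1 group D member 1 (Homo sapiens), read by a luciferase reporter, with a stated time of 24 h; on this read-out higher numbers stand for an effect only at larger amounts of compound and lower numbers for an effect already at smaller amounts. In this assay compound 2 gives 3000 nM. Among the compounds with values here, this is the lowest of the two numbers measured so far. Compound 3 `O=[N+]([O-])c1ccc(CN(Cc2ccc(Cl)cc2)Cc2ccc3ccccc3c2)s1` replaces that group with a naphthalen-2-ylmethyl substituent, and in this assay compound 3 gives 8800 nM, a higher number than that of compound 2, and the gap between them lies beyond the usual scatter. Compound 1 `CC(C)(C)OC(=O)CN(Cc1ccc(Cl)cc1)Cc1nc2ccccc2s1` has no reported result in this assay, for compound 1 the entry is "not determined" (no result reported), so it adds nothing to the numbers.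

Compound 4 `O=[N+]([O-])c1ccc(CN(Cc2ccc(Cl)cc2)Cc2nc3ccccc3s2)s1` has not yet been measured. It differs from compound 2 by 1,3-benzothiazol-2-yl in place of carbamoyl on a saturated chain carbon bound to an amine nitrogen. Within the data shown here, since the only measured comparison shows a larger aromatic substituent at this position with a higher number, the expected step from compound 2 to compound 4 is estimated as a 2.0-fold higher number from compound 2 to compound 4 (0.30 log units; within the scatter), towards a higher number. On this basis compound 4 is expected to give about 6000 nM in this assay, with a likely range from 2000 nM to 20000 nM.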

Compound 4, half-maximal effective concentration: 4000 nM
The estimate for compound 4 lay 1.5-fold (0.18 log units) above the measured number; the measured number falls inside the stated range.
By their numbers in this assay, from the lowest: compounds 2 and 4 (each within the scatter of the next); then compound 3.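

In this assay the exchange of carbamoyl for 1,3-benzothiazol-2-yl on a saturated chain carbon bound to an amine nitrogen gives a 1.3-fold higher number from compound 2 to compound 4 (0.12 log units; within the scatter) and so stays within the scatter, which shows that this place accepts a fused aromatic pair of rings in place of a small group with no ring and that the amide's hydrogen-bond donor is not required to keep the number in this range. The earlier link between a larger aromatic substituent and a higher number therefore does not hold generally: compound 3 fits it, while compound 4 goes against it. Nothing shown here explains this result.

The compounds shown leave open how a carboxylic acid, an amine or a single phenyl ring would behave at this place. They also leave open whether the ring nitrogen and sulfur of the 1,3-benzothiazol-2-yl group matter.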